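Adding a Second Chloro to the Benzyl Arm

The source may report more compounds than this note shows. Statements on the series, on what has been measured and on what is new or still open speak of the compounds shown alone.

Measured compounds:
- compound 1, `CCN(CC)Cc1ccc2nc(NC(=O)N/N=C/c3cn(Cc4ccccc4Cl)c4ccccc34)sc2c1`: 900 nM
- compound 2, `CN(C)Cc1ccc2nc(NC(=O)N/N=C/c3cn(Cc4ccccc4Cl)c4ccccc34)sc2c1`: 1180 nM
- compound 3, `CC1CCN(Cc2ccc3nc(NC(=O)N/N=C4\C(=O)Nc5ccc(F)cc54)sc3c2)CC1`: "not determined" (no result reported)

In a functional assay on MDA-MB-231 cells (Homo sapiens) for cytotoxicity, read by MTT assay, with a stated time of 72 h (on this read-out higher numbers stand for weaker inhibition and lower numbers for stronger inhibition), compound 1 gives the lowest of the two reported numbers, and compound 2 sits close to it: the step of a 1.3-fold higher number from compound 1 to compound 2 (0.12 log units; within the scatter) lies within the scatter, so the two cannot be told apart. Compound 3 carries no number at all.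

Compound 4, `CCN(CC)Cc1ccc2nc(NC(=O)N/N=C/c3cn(Cc4ccc(Cl)cc4Cl)c4ccccc34)sc2c1`, differs from compound 1 in one place: chloro in place of hydrogen on an aromatic carbon. The change sits on the 2-chlorobenzyl group, turning it into a 2,4-dichlorobenzyl group, on the aromatic carbon meta to a chloro group and para to a large group. Among the compounds with values here, the only measured step, from compound 1 to compound 2, swaps amines on the other end of the molecule and says nothing about this position, so no step bears on the change. With nothing to point either way, a step in this assay of no more than the scatter is expected, and the estimate for compound 4 is 800 nM, with a range from 350 nM to 1800 nM, meaning an expected step of a 1.1-fold lower number from compound 1 to compound 4 (0.05 log units; within the scatter).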

Compound 4, half-maximal inhibitory concentration: 3280 nM
For compound 4 the middle estimate is 4.1-fold (0.61 log units) below the measured one, and the stated range ends below it.
By their numbers in this assay, from the lowest: compounds 1 and 2 (each within the scatter of the next); then compound 4.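

The carbon para to the large group on the benzyl arm is not a neutral place to add a chloro: in this assay the change to a 2,4-dichlorobenzyl group gives a 3.6-fold higher number from compound 1 to compound 4 (0.56 log units; beyond the scatter), a modest step but one beyond the scatter. On this read-out, a higher number means weaker inhibition, so the second chloro weakens the result in this one pair. The earlier compounds shown here differed only in the amine at the other end of the molecule, so they could not show this. Nothing measured here explains the loss.

A fluoro, a methyl or a methoxy on the same carbon could show whether the loss is particular to chloro. On these data alone, it also remains open whether the second chloro has a similar effect when the dimethylamino group of compound 2 replaces the diethylamino group.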